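This account rests on a few compounds, and the source may have more. Where it says the series, first, only, none or still open, it means among the compounds named here.

In a functional assay on HCT-116 cells (Homo sapiens) for antiproliferative activity, read by MTT assay (a lower number here means a stronger inhibitor, a higher number a weaker inhibitor), three compounds that share one core have been measured, and a fourth awaits its turn. Compound 1 `CNC(=O)c1ccc(Oc2cccc(NC(=S)Nc3ccc(F)cc3)c2)nc1` gives 39400 nM in this assay. Compound 2 `CNC(=O)c1ccc(Oc2cccc(NC(=S)Nc3ccc(F)c(C(F)(F)F)c3)c2)nc1` gives 19000 nM. Compound 3 `CNC(=O)c1ccc(Oc2cccc(NC(=S)Nc3cc(C(F)(F)F)cc(C(F)(F)F)c3)c2)nc1` gives 2500 nM and stands lowest of the three numbers.

Compound 2 and compound 1 differ in one place only: hydrogen in place of trifluoromethyl on an aromatic carbon. This change gave a 2.1-fold higher number from compound 2 to compound 1 (0.32 log units; beyond the scatter). How the core of compound 3 differs from that of compound 2 is not broken down here; their two values simply show compound 3 well below compound 2.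

Compound 4 `CNC(=O)c1ccc(Oc2cccc(NC(=S)Nc3cccc(C(F)(F)F)c3)c2)nc1` is the unmeasured member. It differs from compound 3 in one place: hydrogen in place of trifluoromethyl on an aromatic carbon. Going by the values given here, this is the same kind of change as the one from compound 2 to compound 1, but not the same: there the hydrogen entered at a position ortho to a fluoro group and meta to a large group, whereas here it enters at a position meta to a large group and meta to a trifluoromethyl group. The expected step from compound 3 to compound 4 is a 3.6-fold higher number from compound 3 to compound 4 (0.56 log units; beyond the scatter), somewhat larger than the earlier one. This expectation rests on the fact that compound 1 and compound 2 both sit far above compound 3, which gives 2500 nM. For compound 4 the estimate in this assay is 9000 nM, expected to lie between 3500 nM and 25000 nM.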

Compound 4, half-maximal inhibitory concentration: 36700 nM
Compound 4: middle estimate off by 4.1-fold (0.61 log units), on the low side; measured number above the stated range.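

Putting hydrogen in place of trifluoromethyl raises the number on both cores in this assay, but the size of the step does not carry over from one core to the other: the same change on two cores in this assay, a 2.1-fold higher number (0.32 log units; beyond the scatter) from compound 2 to compound 1 and a 15-fold higher number (1.17 log units; beyond the scatter) from compound 3 to compound 4, 7.1-fold (0.85 log units) apart, beyond the scatter of two such steps.

The step of a 15-fold higher number from compound 3 to compound 4 (1.17 log units; beyond the scatter) is large, whereas a 1.9-fold higher number from compound 2 to compound 4 (0.29 log units; within the scatter) and a 1.1-fold lower number from compound 1 to compound 4 (0.03 log units; within the scatter) are small enough that these pairs cannot be told apart. Within this small set, then, the low number of compound 3 is lost once one of its two trifluoromethyl groups is gone, and what remains matches the weak compounds. Going by these compounds alone, these results rest on only two cores, so they show that the effect of this change depends on its surroundings, but they do not show why, nor do they give a rule for predicting its size on another core.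

The compounds shown leave open how a chloro group, a methoxy group, an amine or a carboxylic acid would behave in the place of trifluoromethyl on this ring. As far as these compounds go, it also remains open whether a third core would give a step closer to the small one or the large one.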